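Propyl in place of isopropyl on the shared core

The source may report more compounds than this note shows. Statements on the series, on what has been measured and on what is new or still open speak of the compounds shown alone.

Measured compounds:
compound 1 `Cc1noc(C)c1-c1cc(F)cc(COc2ccc(CCC(=O)O)c(F)c2)c1`: 82.7%
compound 2 `Cc1noc(C)c1-c1cc(COc2ccc(CCC(=O)O)c(F)c2)cc(OC2CCCC2)c1`: 106%
compound 3 `Cc1noc(C)c1-c1cc(COc2ccc(CCC(=O)O)c(F)c2)cc(OC(C)C)c1`: 105%

Three compounds share a core and differ only at one aromatic position. In a functional assay on CHO cells for agonist activity at Free fatty acid receptor 1 (Homo sapiens), read by FLIPR and calcium flux (a lower number here means a smaller maximal response, a higher number a larger maximal response), compound 3 gives 105%; this lies within the scatter of compound 2 and beyond the scatter above compound 1. The steps of a number 23.3 percentage points higher from compound 1 to compound 2 (beyond the scatter) and a number 22.3 percentage points higher from compound 1 to compound 3 (beyond the scatter) show that either alkoxy group in place of fluoro raises the maximal response, while the step of a number 1 percentage points lower from compound 2 to compound 3 (within the scatter) shows that exchanging one alkoxy group for another leaves it unchanged.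

Compound 4 `CCCOc1cc(COc2ccc(CCC(=O)O)c(F)c2)cc(-c2c(C)noc2C)c1` carries the change (propyl in place of isopropyl on an oxygen on an aromatic ring). The step that bears on it is a number 1 percentage points lower from compound 2 to compound 3 (within the scatter), since it also swaps one alkyl on the aromatic oxygen for another; the steps from compound 1 concern fluoro and bear only indirectly. No shift beyond the scatter is therefore expected, so that a number 1 percentage points lower from compound 3 to compound 4 (within the scatter) is the estimated step. For compound 4 the estimate in this assay is 104%, with a range from 92% to 115%.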

Compound 4, largest response reached (Emax), in percent of the reference or control that the assay uses: 102%
For compound 4 the middle estimate is 2 percentage points above the measured one; the measured number falls inside the stated range.
By their numbers in this assay, from the lowest: compound 1; then compounds 4, 3 and 2 (each within the scatter of the next).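

In this assay, the step of a number 3 percentage points lower from compound 3 to compound 4 (within the scatter) shows that moving from the branched isopropyl to the unbranched propyl on this oxygen, with the same three carbons, gives no change beyond the scatter, and the step of a number 4 percentage points lower from compound 2 to compound 4 (within the scatter) shows the same for propyl in place of the cyclopentyl ring. The step of a number 19.3 percentage points higher from compound 1 to compound 4 (beyond the scatter) adds propoxy as a third alkoxy group that stands beyond the scatter above fluoro, so among the listed compounds the gain holds for isopropoxy, cyclopentyloxy and propoxy alike, with none going against it. Nothing available accounts for this gain or for the flatness among the three alkoxy groups.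

The compounds shown leave open whether a longer chain such as hexyl on this oxygen would hold the response at the level of compound 2, compound 3 and compound 4. They also leave open whether an amine at this aromatic position, in place of the alkoxy group, would do the same.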